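The source may hold more compounds than are shown below. What is called first, only, known or untested is meant among the compounds shown, and "the series" means these compounds.

Among the measured compounds shown here, in a functional assay on A549 cells (Homo sapiens) for cytotoxicity, read by sulforhodamine B assay, with a stated time of 48 h (on this read-out higher numbers stand for weaker inhibition and lower numbers for stronger inhibition), compound 3 `COc1ccc(/C=C/C(=O)c2cccc(-c3cccc(F)c3)c2)cc1OC` gives 1940 nM, the lowest of the three numbers measured so far. Compound 1 `COc1ccc(/C=C/C(=O)c2cccc(-c3cccc(F)c3)c2)cc1` gives 2440 nM, and the step of a 1.3-fold lower number from compound 1 to compound 3 (0.10 log units; within the scatter) lies within the scatter. Compound 2 `COc1ccc(/C=C/C(=O)c2ccc(N)c(-c3ccc(F)cc3)c2)cc1OC` gives 8630 nM, a number beyond the scatter from compound 3; compound 2 differs from compound 3 in more than one place, so its value shows only that much. Compound 4 `COc1ccc(/C=C/C(=O)c2cccc(-c3ccc(F)cc3)c2)cc1OC` differs from compound 3 in one place: 4-fluorophenyl in place of 3-fluorophenyl on an aromatic carbon. For the measured compounds named here, no measured step changes only the position of the fluorine on the outer ring, so there is no direct guide for this change. The step of a 1.0-fold higher number from compound 3 to compound 4 (0.01 log units; within the scatter) is therefore expected to stay within the scatter. Compound 4 is estimated at 2000 nM, in a range from 900 nM to 4500 nM.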

Compound 4, half-maximal inhibitory concentration: 11800 nM
The estimate for compound 4 lay 5.9-fold (0.77 log units) below the measured number; measured number above the stated range.
By their numbers in this assay, from the lowest: compounds 3 and 1 (each within the scatter of the next); then compounds 2 and 4 (each within the scatter of the next).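

In this assay, the place of the fluorine on the outer ring matters: 4-fluorophenyl in place of 3-fluorophenyl gives a 6.1-fold higher number from compound 3 to compound 4 (0.78 log units; beyond the scatter) even though the atoms stay the same. With 4-fluorophenyl in place, hydrogen in place of amino gives a 1.4-fold higher number from compound 2 to compound 4 (0.14 log units; within the scatter) and so no change that can be told from scatter. Nothing measured here explains the fluorine effect.

From the compounds shown here alone, whether amino would also make no difference alongside 3-fluorophenyl stays open. So does the effect of chlorine in place of fluorine on the outer ring.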